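This account rests on a few compounds, and the source may have more. Where it says the series, first, only, none or still open, it means among the compounds named here.

Measured compounds:
compound 1 `CC(C)(C)OC(=O)N1CCC(CCCNc2ccc3c(c2)CCS3(=O)=O)CC1` gives 83% in a functional assay on CHO-K1 cells for agonist activity at Glucose-dependent insulinotropic receptor (Mus musculus), read by HTRF and cAMP accumulation, with a stated time of 30 min; a lower number here means a smaller maximal response, a higher number a larger maximal response
compound 2 `CC(C)(C)OC(=O)N1CCC(CCCNc2ccc3c(c2)OCC3=O)CC1` gives 108% in this assay

Of these two, compound 2 stands highest in this assay; the nearest number, that of compound 1, lies lower by a gap beyond the scatter. For the measured compounds named here, no more than that can be said of the pair, since the two cores differ and no step between them has been worked out.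

The account now turns to compound 3 `COC(=O)c1cnc(N2CCC(CCCNc3ccc4c(c3)OCC4=O)CC2)nc1`, which is not yet measured. It keeps the core of compound 2 and alters only the group on the ring nitrogen: 5-(methoxycarbonyl)pyrimidin-2-yl in place of tert-butoxycarbonyl on an amine nitrogen in a ring

With no comparable exchange measured among these compounds, the expectation can rest on compound 2 alone and on its value of 108%, and the step from compound 2 to compound 3 is expected to be a number 8 percentage points lower from compound 2 to compound 3 (within the scatter), that is no change beyond the scatter. For compound 3 the maximal response in this assay is estimated at 100%, with a range from 72% to 125%.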

Compound 3, largest response reached (Emax), in percent of the reference or control that the assay uses: 67%
Beside the measured number, compound 3's estimate is 33 percentage points above it; measured number outside the range, below it.
By their numbers in this assay, from the lowest: compound 3; then compound 1; then compound 2.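

Held on the core of compound 2, the exchange of tert-butoxycarbonyl for 5-(methoxycarbonyl)pyrimidin-2-yl on the amine nitrogen in the ring gives a number 41 percentage points lower from compound 2 to compound 3 (beyond the scatter) in this assay and is the only step here that changes one place alone. It shows that the maximal response depends on the group at this position, which compound 1 and compound 2 could not show, since their cores differ. Nothing shown here accounts for the size of this step.

Still open, going by these compounds, is whether the loss follows the aromatic ring or the ester, a question that a carboxylic acid in place of the methoxycarbonyl, or an isopropoxycarbonyl on the ring nitrogen, could help to settle. On these data alone, it is also open whether the same exchange on the core of compound 1 would lower the response to a like degree.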